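Swapping a piperazinylethyl tail for piperidinyl in compound 1

The compounds below may be only part of what the source reports. "The series", "measured", "known", "first", "only" and "open" are said of these compounds alone.

Measured compounds:
compound 1 `O=C1c2c[n+]([O-])c3ccccc3c2C(=O)c2c1c1ccccc1n2CCCCN1CCNCC1` gives 12000 nM in a functional assay on MCF7 cells (Homo sapiens) for cytotoxicity, read by MTT assay, with a stated time of 72 h; on this read-out lower numbers stand for stronger inhibition and higher numbers for weaker inhibition.
compound 2 `CC1(C)OC[C@@H](Cn2cc(Cn3c4c(c5ccccc53)C(=O)c3c[n+]([O-])c5ccccc5c3C4=O)nn2)O1` gives > 1000 nM in this assay; this is a limit of the assay and not a number.

Among the measured compounds shown here, compound 1 carries the only plain number in this assay, so it is the one fixed point (the limit of > 1000 nM in this assay, at which 1 of the 2 values shown sits). Compound 3 `O=C1c2c[n+]([O-])c3ccccc3c2C(=O)c2c1c1ccccc1n2CCN1CCCCC1` has not yet been measured. It differs from compound 1 in one place (piperidin-1-yl in place of 2-(piperazin-1-yl)ethyl on a saturated chain carbon, two bonds along the chain from an aromatic nitrogen).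

For the measured compounds named here, no step between two measured compounds is available, so nothing shows how such a change moves the read-out. The shared core stays the same, and the tail becomes shorter with one fewer ring nitrogen. The step of a 1.2-fold lower number from compound 1 to compound 3 (0.08 log units; within the scatter) is expected to stay within the usual scatter, with no clear direction. Compound 3 is therefore expected to give about 10000 nM in this assay, with a range from 3000 nM to 35000 nM, anchored on compound 1 at 12000 nM.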

Compound 3, half-maximal inhibitory concentration: 620 nM
Estimate against measurement, compound 3: 16-fold (1.21 log units) above, and the stated range ends above it.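

In this assay, among the compounds shown here, replacing the 4-(piperazin-1-yl)butyl tail with 2-(piperidin-1-yl)ethyl gives a 19-fold lower number from compound 1 to compound 3 (1.29 log units; beyond the scatter), the first readable step. It shows that the tail on the aromatic nitrogen of the shared core is a place where a single change can strongly alter cytotoxicity in these cells, and that this change moves the number towards stronger inhibition. Nothing given here explains why the step is so large.

The chain and the ring change together in this step, so the compounds shown cannot separate the effect of the shorter tail from that of losing a ring nitrogen. A 4-(piperidin-1-yl)butyl tail or a 2-(piperazin-1-yl)ethyl tail on the same core would pull these two parts apart.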